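This account rests on a few compounds, and the source may have more. Where it says the series, first, only, none or still open, it means among the compounds named here.

In a functional assay on HCT-116 cells (Homo sapiens) for inhibition, read by MTT assay, with a stated time of 48 h (on this read-out higher numbers stand for weaker inhibition and lower numbers for stronger inhibition), compound 2 (`COc1ccc(CN(C(C)=O)c2cc(OC)c(OC)c(OC)c2)cc1O`) gives 270 nM and compound 1 (`COCC(=O)N(Cc1ccc(OC)c(O)c1)c1cc(OC)c(OC)c(OC)c1`) gives 230 nM, so the two stand within the scatter of each other. The next analogue, compound 3 (`COc1ccc(CN(C(=O)C(C)Br)c2cc(OC)c(OC)c(OC)c2)cc1O`), has 1-bromoethyl in place of methyl on a carbonyl carbon. Among the measured compounds shown here, the only measured step on this side of the amide, a 1.2-fold higher number from compound 1 to compound 2 (0.07 log units; within the scatter), involves no bromine and offers little guidance. A moderate move to a lower number is expected in this assay, with wide uncertainty: the expected change is a 3.0-fold lower number from compound 2 to compound 3 (0.48 log units; beyond the scatter). For compound 3 the estimated value is 90 nM, with an expected range of 15 nM to 400 nM.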

Compound 3, half-maximal inhibitory concentration: 140 nM
Estimate against measurement, compound 3: 1.6-fold (0.19 log units) below; low and high end bracket the measured number.
By their numbers in this assay, from the lowest: compounds 3, 1 and 2 (each within the scatter of the next).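

In this assay 1-bromoethyl in place of methyl on a carbonyl carbon gives a 1.9-fold lower number from compound 2 to compound 3 (0.29 log units; within the scatter) and 1-bromoethyl in place of methoxymethyl gives a 1.6-fold lower number from compound 1 to compound 3 (0.22 log units; within the scatter) at that same carbon. Methyl, methoxymethyl and 1-bromoethyl therefore read alike at this position, and the bromine-bearing group brings no change that stands clear of the scatter. No supporting measurement bears on this result. As far as these compounds go, whether an ethyl group would read the same as 1-bromoethyl remains open. So does the effect of an amine or a carboxylic acid on this carbonyl carbon.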